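From benzyloxy to cyclopentylsulfanyl on a shared core

This account rests on a few compounds, and the source may have more. Where it says the series, first, only, none or still open, it means among the compounds named here.

Compound 1, `CCCCCCOc1nc(C(C)(C)C)ccc1CNC(=O)C(C)c1ccc(NS(C)(=O)=O)c(F)c1`, gives 2.7 nM in an assay on cells for antagonist activity at transient receptor potential cation channel subfamily V member 1 (Homo sapiens), read by FLIPR and calcium flux, with a stated time of 6 min; a lower number here means a stronger inhibitor, a higher number a weaker inhibitor.
Compound 2, `CC(C)CCOc1nc(C(C)(C)C)ccc1CNC(=O)C(C)c1ccc(NS(C)(=O)=O)c(F)c1`, gives 0.8 nM in this assay.
Compound 3, `CC(C(=O)NCc1ccc(C(C)(C)C)nc1OCc1ccccc1)c1ccc(NS(C)(=O)=O)c(F)c1`, gives 4.4 nM in this assay.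

Of the three measured compounds, compound 3 carries the highest number. Its nearest neighbour is compound 1, with a 1.6-fold higher number from compound 1 to compound 3 (0.21 log units; within the scatter), so those two cannot be ordered; compound 2 lies further off, with a 5.5-fold higher number from compound 2 to compound 3 (0.74 log units; beyond the scatter). Compound 4, `CC(C(=O)NCc1ccc(C(C)(C)C)nc1SC1CCCC1)c1ccc(NS(C)(=O)=O)c(F)c1`, differs from compound 3 in one place: cyclopentylsulfanyl in place of benzyloxy on an aromatic carbon. The two steps just named are the ones that bear on this position, since each exchanges a saturated chain for the benzyl group, and both point the same way; a 3.4-fold lower number from compound 1 to compound 2 (0.53 log units; beyond the scatter) shows that the shape of the saturated group also counts. Among the measured compounds shown here, no measured compound tests sulfur in place of the ring oxygen, so that part of the change has no precedent here. The cyclopentyl group is saturated, as are the chains of compound 1, which gives 2.7 nM, and compound 2, which gives 0.8 nM, so a number nearer those is expected for compound 4. Compound 4 is thus expected to give 3 nM in this assay, within a range from 1 nM to 10 nM. The expected step is a 1.5-fold lower number from compound 3 to compound 4 (0.17 log units; within the scatter).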

Compound 4, inhibition constant: 2.5 nM
Compound 4: middle estimate off by 1.2-fold (0.08 log units), on the high side; measured number inside the range.
By their numbers in this assay, from the lowest: compound 2; then compounds 4, 1 and 3 (each within the scatter of the next).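

In this assay, replacing the benzyloxy group on this aromatic carbon, next to the ring nitrogen, with cyclopentylsulfanyl gives no change that can be read (a 1.8-fold lower number from compound 3 to compound 4 (0.25 log units; within the scatter)), and the same holds for the replacement of hexyloxy (a 1.1-fold lower number from compound 1 to compound 4 (0.03 log units; within the scatter)). The position therefore accepts a sulfur link and a five-membered saturated ring while staying within the scatter of both compounds, but the saturated ring does not match the isopentyloxy group, which remains apart by a modest step (a 3.1-fold higher number from compound 2 to compound 4 (0.49 log units; beyond the scatter)). No measurement shown gives a reason for these numbers.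

Compound 4 changes both the linking atom and the group it carries, so the compounds shown cannot separate the contribution of the sulfur from that of the cyclopentyl ring; cyclopentyloxy and isopentylsulfanyl at this position would pull the two apart. They also leave open how a nitrogen link, as in cyclopentylamino, or a smaller ring such as cyclobutyl on sulfur, would compare with the isopentyloxy group of compound 2.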